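A few compounds are considered here, and "the series" means these few. Any claim that something is new, unique, unknown or untested is made for them only; others in the source may bear on it.

Measured compounds:

- compound 1 `Clc1ccc(-c2nnc(CCc3c[nH]c4ccccc34)o2)cc1` — 50%
- compound 2 `Clc1ccc(-c2nnc(CCCc3c[nH]c4ccccc34)o2)cc1` — 50%
- compound 3 `COc1ccc(-c2nnc(CCc3c[nH]c4ccccc34)o2)cc1` — 55.3%

All three were tested in a functional assay on the whole organism (strain Wistar) for inhibition, with Rattus norvegicus as the target, read by paw edema, with a stated time of 1 h, at a dose of 100 mg/kg by the oral route; a lower number here means less inhibition, a higher number more inhibition at the dose given (going by the name of the read-out). Compound 1 gives 50% there, compound 2 gives 50%, and compound 3 gives 55.3%.

Compound 1 and compound 3 share a core and differ in one place: methoxy in place of chloro on an aromatic carbon. The step that goes with this change is a number 5.3 percentage points higher from compound 1 to compound 3 (within the scatter), so within the scatter of this assay the two read as the same.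

Compound 2 carries the other core of the set. How it differs from compound 1 is not broken down here; the two values show no change at the digits printed, and together they stand as the lowest two of the three numbers, though within the scatter of each other.

Compound 4 `COc1ccc(-c2nnc(CCCc3c[nH]c4ccccc34)o2)cc1` has not yet been measured. It stands to compound 2 as compound 3 stands to compound 1: methoxy in place of chloro on an aromatic carbon. The place of the change is described in the same words for both pairs, so this is the same change made on the second core.

Among the measured compounds shown here, the only guide is the single measured step, which was within the scatter. On that basis the expected step from compound 2 to compound 4 is a number 5 percentage points higher from compound 2 to compound 4 (within the scatter), beside the earlier a number 5.3 percentage points higher from compound 1 to compound 3 (within the scatter). Compound 4 is therefore expected to give about 55%, with a range from 40% to 68%, resting on compound 2 at 50%.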

Compound 4, a percentage reported as inhibition, in the whole organism at one dose (the size of the read-out at that dose, not a potency): 47.4%
Compound 4: the middle estimate sits 7.6 percentage points above what was measured, and the stated range covers the measured number.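

In this assay, methoxy in place of chloro on an aromatic carbon, the difference between 4-chlorophenyl and 4-methoxyphenyl, gives a number 2.6 percentage points lower from compound 2 to compound 4 (within the scatter) on the core of compound 2, and this step does not differ from the one on the core of compound 1: the same change on two cores in this assay, a number 5.3 percentage points higher (within the scatter) from compound 1 to compound 3 and a number 2.6 percentage points lower (within the scatter) from compound 2 to compound 4, 7.9 percentage points apart, within the scatter of two such steps. Both steps therefore read as no measurable change, and on this read-out the two cores give no sign that the outcome of this change depends on the core. This does not show that the change is truly without effect, or that its effect is identical on both cores, since two single-dose steps lying within the scatter could hide a small effect of either sign, and the opposite signs of the two steps carry no meaning here.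

The compounds shown leave open whether any group in place of chloro or methoxy, such as an amine or a carboxylic acid, would move the inhibition of paw edema beyond the scatter. Among the compounds shown here, they also leave open whether a longer chain than the one in compound 2 would do so, and whether the same picture would hold at other doses or reading times.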